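This account rests on a few compounds, and the source may have more. Where it says the series, first, only, none or still open, it means among the compounds named here.

Among the compounds with values here, compound 2, `CN(c1nc2ccc(NC(=O)CCc3ccc(C(F)(F)F)cc3)cc2[nH]1)C1CCCC1`, holds the lowest of the two numbers so far in an assay on CHO-K1 cells for displacement of a labelled ligand from melanin-concentrating hormone receptor 1 (Homo sapiens), read by scintillation counting; on this read-out lower numbers stand for stronger inhibition and higher numbers for weaker inhibition. In this assay compound 2 gives 4 nM, while compound 1, `CC(=O)N1CCC(N(C)c2nc3ccc(NC(=O)CCc4ccc(C(F)(F)F)cc4)cc3[nH]2)C1`, gives 30 nM. Within the data shown here, the single measured step, a 7.5-fold lower number from compound 1 to compound 2 (0.88 log units; beyond the scatter), came from putting cyclopentyl in place of 1-acetylpyrrolidin-3-yl on a nitrogen on an aromatic ring.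

Compound 3, `CN(c1nc2ccc(NC(=O)CCc3ccc(C(F)(F)F)cc3)cc2[nH]1)C1CCCCC1`, differs from compound 2 in one place: cyclohexyl in place of cyclopentyl on a nitrogen on an aromatic ring. The cyclopentyl that leaves is the same group whose entry produced the step from compound 1 to compound 2, so that step shows the position is sensitive, but it compared cyclopentyl with a very different group, not with a ring one carbon larger. Among the measured compounds shown here, no measured pair tells how much a change from a five-membered to a six-membered carbon ring at this nitrogen alters the number. For the measured compounds named here, the nearest guidance is therefore only that compound 2 sits at the favourable end of the present range. On that basis compound 3 is expected to stay near compound 2, a step of no change at the digits printed from compound 2 to compound 3 (within the scatter), not clearly beyond the scatter. The estimate for compound 3 in this assay is 4 nM, with a range from 1.5 nM to 12 nM.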

Compound 3, half-maximal inhibitory concentration: 6.7 nM
The estimate for compound 3 lay 1.7-fold (0.22 log units) below the measured number; the measured number falls inside the stated range.
By their numbers in this assay, from the lowest: compounds 2 and 3 (each within the scatter of the next); then compound 1.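

In this assay, within the data shown here, a 1.7-fold higher number from compound 2 to compound 3 (0.22 log units; within the scatter) gives the first measured comparison of two all-carbon rings on this nitrogen, and it does not separate them: cyclohexyl and cyclopentyl cannot be told apart here, so this position accepts the larger ring without a change that can be read. The contrast with the acetylated ring also now holds for a second carbon ring, with a 4.5-fold lower number from compound 1 to compound 3 (0.65 log units; beyond the scatter) on going from 1-acetylpyrrolidin-3-yl to cyclohexyl, so the earlier gap is not particular to cyclopentyl. No measurement at hand offers an explanation for either step.

Going by these compounds, how far this tolerance extends remains open, since a larger carbon ring such as cycloheptyl, an open chain such as isopropyl or a ring holding oxygen such as tetrahydropyran-4-yl could each fall anywhere relative to these values. The step away from 1-acetylpyrrolidin-3-yl also changes the ring nitrogen and the acetyl group together, and a pyrrolidin-3-yl without the acetyl would be needed to tell these two parts apart.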